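Aryl amide variation in a bis-anilide series at mGlu5

The compounds below may be only part of what the source reports. "The series", "measured", "known", "first", "only" and "open" are said of these compounds alone.

Measured so far:
compound 1 `COc1ccccc1C(=O)Nc1cccc(NC(=O)c2ccccc2Cl)c1` — > 30000 nM
compound 2 `COc1ccccc1C(=O)Nc1cccc(NC(=O)c2cc(Cl)cc(Cl)c2)c1` — > 30000 nM

In an in vitro functional assay on HEK293-A cells for antagonist activity at metabotropic glutamate receptor 5 (Rattus norvegicus), read by calcium flux (a lower number here means a stronger inhibitor, a higher number a weaker inhibitor), compound 1 reaches only a limit of the assay, > 30000 nM. Compound 2 in this assay likewise gives only a limit, > 30000 nM. The step that the two limits leave unreadable from compound 1 to compound 2 stays unreadable because of the limit of > 30000 nM in this assay, at which 2 of the 2 values shown sit. Compound 3 `COc1ccccc1C(=O)Nc1cccc(NC(=O)c2ccc(F)cc2)c1` carries 4-fluorophenyl in place of 3,5-dichlorophenyl on a carbonyl carbon. Among the measured compounds shown here, no measured step bears on this change, so no direction can be drawn from the series. Compound 3 is expected to give roughly 40000 nM, with a range from 8000 nM to 200000 nM, and most likely only a limit again. The expected step that the limit leaves unreadable from compound 2 to compound 3 is estimated to lie within the scatter.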

Compound 3, half-maximal inhibitory concentration: > 30000 nM
Compound 3: a limit, no number; the forecaster's own chance of this, stated with the estimate: 80%; the middle value lies beyond the limit too.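

Among the compounds shown here, compound 3 also reaches only a limit, so no step from compound 1 or compound 2 to compound 3 can be read: the limit of > 30000 nM in this assay, at which 3 of the 3 values shown sit. The compounds shown leave open which aryl amide, if any, gives a measurable value in this assay.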